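Indole-linked analogue of compound 2 with an isobutyl amide

A few compounds are considered here, and "the series" means these few. Any claim that something is new, unique, unknown or untested is made for them only; others in the source may bear on it.

Working notes on the series. Compound 1 `CCCNS(=O)(=O)c1ccc(Nc2ncc3c(n2)N(C2CCCC2)[C@H](CC)C(=O)N3C)cc1` gives 278 nM in a functional assay on Huh-7 cells (Homo sapiens) for antiproliferative activity, read by CCK-8 assay, with a stated time of 72 h; on this read-out lower numbers stand for stronger inhibition of growth and higher numbers for weaker inhibition of growth. Compound 3 `CCCCNS(=O)(=O)c1ccc(Nc2ncc3c(n2)N(c2ccn(C)n2)C(CC)C(=O)N3C)cc1`, which carries the same sulfonamide aniline linker, gives 3750 nM in this assay. Compound 2 `CCC1C(=O)N(C)c2cnc(-n3ccc4cc(C(N)=O)ccc43)nc2N1c1ccn(C)n1` replaces that linker with an indole carboxamide and is reported as "not active" (no number reported) in this assay; no single number is known for it, so it stands apart from compound 1 and compound 3 and cannot be placed against their values.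

Compound 4 `CCC1C(=O)N(C)c2cnc(-n3ccc4cc(C(=O)NCC(C)C)ccc43)nc2N1c1ccn(C)n1` differs from compound 2 by one change: isobutyl in place of hydrogen on an amide-type nitrogen. Going by the values given here, no measured pair shows what such a change on the amide nitrogen does, so no size or direction of step in this assay can be taken from the data; the starting point is a compound without a reported number.

Given that compound 2 shows no measurable activity, compound 4 is expected to remain weak, with an estimated value of 8000 nM and a range from 2000 nM to 40000 nM, and a real chance that only a limit is reported.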

Compound 4, concentration for 50% growth inhibition: 5070 nM
Compound 4: middle estimate off by 1.6-fold (0.20 log units), on the high side; low and high end bracket the measured number.
By their numbers in this assay, from the lowest: compound 1; then compounds 3 and 4 (each within the scatter of the next).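

No step can be read from compound 2 to compound 4: in this assay compound 2 is reported without a number, while compound 4 gives 5070 nM. From the compounds shown here alone, what isobutyl on the amide-type nitrogen does to this read-out stays open. No evidence on hand bears on this result.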